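This account rests on a few compounds, and the source may have more. Where it says the series, first, only, none or still open, it means among the compounds named here.

Measured so far in a functional assay on HepG2 cells (Homo sapiens) for antiproliferative activity, read by XTT assay, with a stated time of 72 h; on this read-out higher numbers stand for weaker inhibition and lower numbers for stronger inhibition:

Compound 1 `COc1ncnc2c1c(-c1cc3ccccc3o1)cn2[C@@H]1O[C@H](CO)[C@@H](O)[C@H]1O`: in this assay compound 1 gives > 20000 nM, which is a limit and not a number.
Compound 2 `CNc1ncnc2c1c(-c1cc3ccccc3o1)cn2[C@@H]1O[C@H](CO)[C@@H](O)[C@H]1O`: in this assay compound 2 gives > 20000 nM, again a limit.
Compound 3 `CNc1ncnc2c1c(-c1ccco1)cn2[C@@H]1O[C@H](CO)[C@@H](O)[C@H]1O`: in this assay compound 3 gives 850 nM.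

Compound 3 is the only one of the three with a number. It differs from compound 2 by furan-2-yl in place of 1-benzofuran-2-yl on an aromatic carbon, and this gives an at least 23-fold lower number from compound 2 to compound 3 (1.37 log units; beyond the scatter). Compound 1 differs from compound 2 by methoxy in place of methylamino on an aromatic carbon, and here the step is a step that the two limits leave unreadable from compound 2 to compound 1 because the limit of > 20000 nM in this assay, at which 2 of the 3 values shown sit, is where both values sit.

Compound 4 `COc1ncnc2c1c(-c1ccco1)cn2[C@@H]1O[C@H](CO)[C@@H](O)[C@H]1O` has not been measured. It differs from compound 3 by methoxy in place of methylamino on an aromatic carbon, the same change that leads from compound 2 to compound 1. Since that earlier step cannot be read, the expected size of the step from compound 3 to compound 4 rests only on the number for compound 3; the estimate is a 4.7-fold higher number from compound 3 to compound 4 (0.67 log units; beyond the scatter), with a wide range. In this assay compound 4 is expected to give about 4000 nM, between 1000 nM and 20000 nM.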

Compound 4, half-maximal inhibitory concentration: 300 nM
Beside the measured number, compound 4's estimate is 13-fold (1.12 log units) above it, and the stated range ends above it.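

In this assay, methoxy in place of methylamino gives a 2.8-fold lower number from compound 3 to compound 4 (0.45 log units; beyond the scatter), so on the core of compound 3 the change is readable and modest, but this one pair cannot show that it carries over to another core. Furan-2-yl in place of 1-benzofuran-2-yl gives an at least 66-fold lower number from compound 1 to compound 4 (1.82 log units; beyond the scatter), and the number falls with this change in both the methoxy and the methylamino pairs, so its direction holds across these two cores, though its size is not settled: the same change on two cores in this assay, an at least 23-fold lower number (1.37 log units; beyond the scatter) from compound 2 to compound 3 and an at least 66-fold lower number (1.82 log units; beyond the scatter) from compound 1 to compound 4; the limit leaves it open whether they differ The methoxy step cannot be read on the core of compound 1, and the furan-2-yl steps have no exact size, because of one shared limit: the limit of > 20000 nM in this assay, at which 2 of the 4 values shown sit.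

The compounds shown leave open how an unsubstituted amine, a dimethylamino group or a longer ethoxy chain would compare with methoxy and methylamino in this place. They also leave open how a phenyl group would read in place of furan-2-yl on the shared core.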